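The compounds below may be only part of what the source reports. "The series", "measured", "known", "first", "only" and "open" are said of these compounds alone.

Three amides on a shared core have been tested in a toxicity assay on THP-1 cells (Homo sapiens) for inhibition; a higher number here means that more compound is tolerated, a lower number that less compound is tolerated. Compound 1 `CCCC(=O)Nc1ncc(-c2ccc(OC)cc2)n1C` has a propyl group on its carbonyl carbon, and its > 100000 nM is a limit of the assay, not a number. Compound 2 `COc1ccc(-c2cnc(NC(=O)c3ccno3)n2C)cc1` has 1,2-oxazol-5-yl at that carbon, and its > 100000 nM is also a limit. Compound 3 `COc1ccc(-c2cnc(NC(=O)c3ccccc3F)n2C)cc1` has 2-fluorophenyl there, and its > 100000 nM is again a limit. Compound 3 therefore stands at the limit of > 100000 nM in this assay, at which 3 of the 3 values shown sit.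

Compound 4 `COc1ccc(-c2cnc(NC(=O)c3ccccc3C#N)n2C)cc1` differs from compound 3 in one place, with cyano in place of fluoro on an aromatic carbon, so 2-fluorophenyl becomes 2-cyanophenyl: cyano in place of fluoro on an aromatic carbon.

The measured steps bearing on this change all altered the group on the carbonyl carbon, and none has a readable size. They are a step that the two limits leave unreadable from compound 1 to compound 2, a step that the two limits leave unreadable from compound 1 to compound 3 and a step that the two limits leave unreadable from compound 2 to compound 3. None of them tests the cyano group directly, so they offer only weak guidance. Still, the closest comparison, a step that the two limits leave unreadable from compound 2 to compound 3, shows no measurable departure from the limit, so compound 4 is expected to stay there too. In this assay the expected change, with no direction beyond the scatter, is a number no higher from compound 3 to compound 4 (the limit leaves the size open). For compound 4 the estimated value is 100000 nM, with an expected range from 50000 nM to 200000 nM.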

Compound 4, half-maximal cytotoxic concentration: > 100000 nM
Compound 4 was reported as a limit (the forecaster's own chance of this, stated with the estimate: 85%); the middle value sits exactly at the limit.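

Compound 4, like compound 1, compound 2 and compound 3, is reported in this assay only as a limit, so no step among these four compounds can be read: the limit of > 100000 nM in this assay, at which 4 of the 4 values shown sit. The compounds shown leave open where the half-maximal cytotoxic concentration of each actually lies, and whether the group on the carbonyl carbon changes it at all.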